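Pyridin-3-yl for 5-methylfuran-2-yl: working notes on the series

A few compounds are considered here, and "the series" means these few. Any claim that something is new, unique, unknown or untested is made for them only; others in the source may bear on it.

In a functional assay on MCF7 cells (Homo sapiens) for cytotoxicity, read by ELISA, with a stated time of 4 days (a higher number here means a weaker inhibitor, a lower number a stronger inhibitor), compound 2 `Cc1ccc(-c2cc(-c3ccoc3)cc(-c3ccc(Cl)s3)n2)o1` gives 1900 nM. Compound 1 `Clc1ccc(-c2cc(-c3ccco3)cc(-c3ccc(Cl)s3)n2)cc1` gives 1520 nM, within the scatter of compound 2. For the measured compounds named here, compound 3 `Cc1cccc(-c2cc(-c3ccoc3)cc(-c3ccc(Cl)s3)n2)c1` gives 3990 nM, the only number clearly apart from compound 2, and on the higher side.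

Compound 4 `Clc1ccc(-c2cc(-c3ccoc3)cc(-c3cccnc3)n2)s1` carries pyridin-3-yl in place of 5-methylfuran-2-yl on an aromatic carbon. The change sits on a six-membered aromatic ring with 1 nitrogen, next to the ring nitrogen, while the 5-chlorothiophen-2-yl and furan-3-yl groups stay.

Going by the values given here, one measured step bears on this place: a 2.1-fold higher number from compound 2 to compound 3 (0.32 log units; beyond the scatter), with 3-methylphenyl entering for the same 5-methylfuran-2-yl. That step is modest. Compound 1 differs from compound 2 in more than one place and gives no clean comparison. Pyridin-3-yl also brings a six-membered aromatic ring in place of the five-membered one, so a modest move toward a higher number is expected. Among the compounds with values here, no measured compound carries pyridin-3-yl, which keeps the range wide.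

The estimated change in this assay is a 1.8-fold higher number from compound 2 to compound 4 (0.27 log units; within the scatter). For compound 4 the estimated value is 3500 nM, with an expected range of 1200 nM to 10000 nM.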

Compound 4, half-maximal inhibitory concentration: 3480 nM
Estimate against measurement, compound 4: 1.0-fold (0.00 log units) above; the range from low to high includes it.
By their numbers in this assay, from the lowest: compounds 1, 2, 4 and 3 (each within the scatter of the next, the first and the last beyond it).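

In this assay pyridin-3-yl gives a 1.8-fold higher number from compound 2 to compound 4 (0.26 log units; within the scatter) and, against the other aromatic ring at this place, a 1.1-fold lower number from compound 3 to compound 4 (0.06 log units; within the scatter) so it cannot be separated from either 5-methylfuran-2-yl or 3-methylphenyl. The two groups it is compared with are themselves set apart by a 2.1-fold higher number from compound 2 to compound 3 (0.32 log units; beyond the scatter) and pyridin-3-yl therefore does not add a third distinct level at this position but falls within the scatter of both. At this aromatic carbon, next to the ring nitrogen, a six-membered aromatic ring with a nitrogen in it is thus accommodated with no step beyond the scatter, and nothing at hand gives a reason for these numbers.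

On these data alone, all three groups compared at this place are aromatic rings, so what an amine such as morpholine, a carboxylic acid or a longer alkyl chain would give here stays open, as does the effect of moving the nitrogen to give pyridin-4-yl. The 5-chlorothiophen-2-yl and furan-3-yl groups are the same throughout compound 2, compound 3 and compound 4, which leaves open whether the same picture holds with other groups in those places.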